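Truncated aminoglycoside analogue: cytotoxicity on macrophage cells

This account rests on a few compounds, and the source may have more. Where it says the series, first, only, none or still open, it means among the compounds named here.

Three compounds of the series have been run in a toxicity assay on the whole organism (J774 cells) for cytotoxicity, with Mus musculus as the target, read by MTT assay, with a stated time of 24 h, tested at 10 uM; a lower number here means a stronger effect, a higher number a weaker effect of the compound at the concentration tested. Compound 1 `CCCCCCCCCO[C@@H]1[C@@H](N)[C@@H](O[C@H]2[C@H](O)[C@@H](O)[C@H](N)C[C@@H]2N)O[C@H](CN)[C@H]1OCCCCCCCCC` gives 82.7%. Compound 2 `CCCCCCCCCO[C@@H]1[C@@H](N)[C@@H](O[C@H]2[C@H](O)[C@@H](OCCCCCCCCC)[C@H](N)C[C@@H]2N)O[C@H](CN)[C@H]1O` gives 78.4%, and compound 3 `NC[C@H]1O[C@H](O[C@H]2[C@H](O)[C@@H](OCc3ccc4ccccc4c3)[C@H](N)C[C@@H]2N)[C@H](N)[C@@H](OCc2ccc3ccccc3c2)[C@@H]1O` gives 86%. On these three numbers compound 1 stands second highest; its gap to compound 3 and its gap to compound 2 both lie within the scatter, so no order among the three can be read from them.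

Compound 4 `CCCCCCCCCO[C@@H]1[C@@H](N)[C@@H](OC[C@H](O)CN)O[C@H](CN)[C@H]1OCCCCCCCCC` has not yet been measured in this assay. It differs from compound 1 in one place: 3-amino-2-hydroxypropyl in place of 4,6-diamino-2,3-dihydroxycyclohexyl on an oxygen on a saturated carbon. The two nonyl chains and the remaining core of compound 1 are kept; only the substituent on that oxygen is exchanged.

Among the compounds with values here, no step between measured compounds is known, and all three measured values sit close together, so for compound 4 a step from compound 1 that stays within the scatter, or at most slightly downward, is expected: a number 2.7 percentage points lower from compound 1 to compound 4 (within the scatter). Compound 4 is therefore estimated at 80%, with a range from 65% to 93% in this assay.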

Compound 4, a percentage reported as activity, at one concentration (the size of the read-out at that concentration, not a potency): 88%
Beside the measured number, compound 4's estimate is 8 percentage points below it; the range from low to high includes it.
By their numbers in this assay, from the lowest: compounds 2, 1, 3 and 4 (each within the scatter of the next).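

Within the data shown here, replacing 4,6-diamino-2,3-dihydroxycyclohexyl with 3-amino-2-hydroxypropyl on an oxygen on a saturated carbon gives the first step in this assay: a number 5.3 percentage points higher from compound 1 to compound 4 (within the scatter). With the two nonyl chains kept, this exchange of a ring of 10 heavy atoms for an open substituent of 5 heavy atoms therefore brings no readable change at the concentration tested. Nothing measured here bears on the reason for this result.

Going by these compounds, whether the same exchange stays within the scatter on the pattern of compound 2, or with the 2-naphthylmethyl groups of compound 3, remains open. Also open, on these data alone, is how 2-aminoethyl in place of 3-amino-2-hydroxypropyl, or dodecyl chains in place of the two nonyl chains, would read in this assay.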